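The source may report more compounds than this note shows. Statements on the series, on what has been measured and on what is new or still open speak of the compounds shown alone.

Series notes. Within the data shown here, compound 2 `CSc1nc2ccc(C)cn2c(=N)c1S(=O)(=O)c1ccccc1` carries a methyl where compound 1 `CSc1nc2ccc(F)cn2c(=N)c1S(=O)(=O)c1ccccc1` carries a fluoro; in an assay on HeLa cells for displacement of a labelled ligand from 5-hydroxytryptamine receptor 6 (Homo sapiens) (a higher number here means a weaker inhibitor, a lower number a stronger inhibitor), compound 1 gives 28 nM and compound 2 gives 1.3 nM, the lowest of the two numbers so far, with the step of a 22-fold lower number from compound 1 to compound 2 (1.33 log units; beyond the scatter) beyond the scatter. Compound 3 `CSc1nc2ccc(C(N)=O)cn2c(=N)c1S(=O)(=O)c1ccccc1` differs from compound 2 by carbamoyl in place of methyl on an aromatic carbon. Among the measured compounds shown here, no measured step covers a carbamoyl at this carbon; only the fluoro-to-methyl step shows that the position is sensitive, so the expectation is loosely anchored. For compound 3 a step of a 7.7-fold higher number from compound 2 to compound 3 (0.89 log units; beyond the scatter) is expected, giving an estimate of 10 nM with a range of 2 nM to 60 nM.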

Compound 3, half-maximal inhibitory concentration: 8.8 nM
Estimate against measurement, compound 3: 1.1-fold (0.06 log units) above, within the range that was stated.
By their numbers in this assay, from the lowest: compound 2; then compound 3; then compound 1.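

A carbamoyl is accepted at this aromatic carbon, and the position does not simply reject a group with a hydrogen-bond donor and acceptor: the number stays better than with fluoro (a 3.2-fold lower number from compound 1 to compound 3 (0.50 log units; beyond the scatter)). It still falls short of methyl (a 6.8-fold higher number from compound 2 to compound 3 (0.83 log units; beyond the scatter)), so methyl gives the lowest number of the three groups at this carbon. Nothing measured here explains this order.

From the compounds shown here alone, whether the amide hydrogens matter remains open, as a nitrile or a carboxylic acid at this carbon would test. So does whether an ethyl or a longer chain improves on methyl.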